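Truncating the Amine Side Chain in a Hindered-Phenol Series

The source may hold more compounds than are shown below. What is called first, only, known or untested is meant among the compounds shown, and "the series" means these compounds.

Measured compounds:
- compound 1, `CN(CCCN1C(=O)CSC1c1cc(C(C)(C)C)c(O)c(C(C)(C)C)c1)CC1CC1`, in a functional assay on aorta for inhibition of Voltage-dependent L-type calcium channel subunit alpha-1C (Rattus norvegicus) (on this read-out lower numbers stand for stronger inhibition and higher numbers for weaker inhibition), gives 1200 nM
- compound 2, `CN(C)CCN(C)CCCN1C(=O)CSC1c1cc(C(C)(C)C)c(O)c(C(C)(C)C)c1`, in this assay gives 1700 nM

Among the compounds with values here, compound 2 holds the highest of the two numbers so far, but its gap to compound 1 is within the scatter, so the two cannot be ordered. Within the data shown here, the only step in hand, a 1.4-fold higher number from compound 1 to compound 2 (0.15 log units; within the scatter), shows that swapping one substituent for another on the saturated chain carbon bound to the amine nitrogen left the read-out essentially unchanged.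

Compound 3, `CN(C)CCCN1C(=O)CSC1c1cc(C(C)(C)C)c(O)c(C(C)(C)C)c1`, takes this position one step further: hydrogen in place of (dimethylamino)methyl on a saturated chain carbon bound to an amine nitrogen. Among the measured compounds shown here, no measured step covers a removal of this group outright, so the expectation rests on compound 2, whose value of 1700 nM shifted little in the step from compound 1. Compound 3 is therefore expected to land close to compound 2, with a 1.3-fold higher number from compound 2 to compound 3 (0.11 log units; within the scatter) as the estimated step. Compound 3 is estimated at 2200 nM, within 900 nM to 5500 nM.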

Compound 3, half-maximal inhibitory concentration: 1500 nM
For compound 3 the middle estimate is 1.5-fold (0.17 log units) above the measured one; the range from low to high includes it.
By their numbers in this assay, from the lowest: compounds 1, 3 and 2 (each within the scatter of the next).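

With compound 3, the group on the saturated chain carbon bound to an amine nitrogen is reduced to hydrogen, and in this assay removing (dimethylamino)methyl gives a 1.1-fold lower number from compound 2 to compound 3 (0.05 log units; within the scatter). Set against cyclopropyl at the same place, hydrogen gives a 1.3-fold higher number from compound 1 to compound 3 (0.10 log units; within the scatter), so all three compounds lie within the scatter and neither group is needed for a number in this range. Nothing available here explains why these changes leave the read-out unresolved.

The compounds shown leave open whether the dimethylamino group itself matters, since a primary amine, a carboxylic acid or a longer chain in its place could behave differently. They also leave open whether any change on this side chain can move the number beyond the scatter.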